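This account rests on a few compounds, and the source may have more. Where it says the series, first, only, none or still open, it means among the compounds named here.

Within the data shown here, compound 3, `N#Cc1cccc(-n2cc(COc3cccc(NC(=O)Nc4ccc(Cl)c(C(F)(F)F)c4)c3)nn2)c1`, stands second highest of the three numbers so far in a functional assay on HepG2 cells (Homo sapiens) for inhibition, read by MTT assay, with a stated time of 72 h; a lower number here means a stronger inhibitor, a higher number a weaker inhibitor: compound 3 gives 2760 nM, compound 1, `COc1cccc(-n2cc(COc3cccc(NC(=O)Nc4ccc(Cl)c(C(F)(F)F)c4)c3)nn2)c1`, gives 1310 nM, and compound 2, `Cc1cccc(-n2cc(COc3cccc(NC(=O)Nc4ccc(Cl)c(C(F)(F)F)c4)c3)nn2)c1`, gives 7270 nM. The steps among them were all modest: a 5.5-fold higher number from compound 1 to compound 2 (0.74 log units; beyond the scatter), a 2.1-fold higher number from compound 1 to compound 3 (0.32 log units; beyond the scatter) and a 2.6-fold lower number from compound 2 to compound 3 (0.42 log units; beyond the scatter). Compound 4, `CCc1ccccc1-n1cc(COc2cccc(NC(=O)Nc3ccc(Cl)c(C(F)(F)F)c3)c2)nn1`, differs from compound 3 in one place: 2-ethylphenyl in place of 3-cyanophenyl on an aromatic nitrogen. Among the measured compounds shown here, no measured step covers exactly this exchange. The nearest guide is the alkyl group of compound 2, whose number was the highest of the three; the step of a 2.6-fold lower number from compound 2 to compound 3 (0.42 log units; beyond the scatter) shows that replacing an alkyl group with a nitrile lowered the number, so the reverse direction, nitrile to alkyl, is expected to raise it. For the measured compounds named here, compound 4 also carries its group at a different position of the phenyl ring, for which no measured pair gives guidance, so the expectation is wide. A modest rise is expected for compound 4 in this assay, roughly a 2.5-fold higher number from compound 3 to compound 4 (0.40 log units; beyond the scatter). Compound 4 is therefore estimated at 7000 nM, with a likely range from 2500 nM to 20000 nM.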

Compound 4, half-maximal inhibitory concentration: 3530 nM
Compound 4: the middle estimate sits 2.0-fold (0.30 log units) above what was measured; the range from low to high includes it.
By their numbers in this assay, from the lowest: compound 1; then compounds 3 and 4 (each within the scatter of the next); then compound 2.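

In this assay, 2-ethylphenyl in place of 3-cyanophenyl on the aromatic nitrogen gives a 1.3-fold higher number from compound 3 to compound 4 (0.11 log units; within the scatter), so at this position the nitrile and its hydrogen-bond acceptor can be exchanged for an all-carbon group without a change that can be read. Alkyl-bearing phenyl groups do not all read alike here: 2-ethylphenyl in place of 3-methylphenyl gives a 2.1-fold lower number from compound 2 to compound 4 (0.31 log units; beyond the scatter), which shows that an alkyl group alone does not set the number. With 2-ethylphenyl in place of 3-methoxyphenyl there is a 2.7-fold higher number from compound 1 to compound 4 (0.43 log units; beyond the scatter), and compound 1 keeps the lowest number of the four.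

Nothing available explains these differences. Going by these compounds, it remains open whether the step between compound 2 and compound 4 follows from the ethyl group or from its place on the phenyl ring, and how an amine or a carboxylic acid on that ring would read.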